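From hydroxy to bromo: a single group exchanged

This account rests on a few compounds, and the source may have more. Where it says the series, first, only, none or still open, it means among the compounds named here.

Compound 1 `CC1(C)[C@H]2CC[C@]1(C)N(Cc1cn(-c3cccc(Cl)c3)nn1)C(=O)C2`: 260 nM
Compound 2 `CC1(C)[C@H]2CC[C@]1(C)N(Cc1cn(-c3cccc(O)c3)nn1)C(=O)C2`: 280 nM
Compound 3 `CC1(C)[C@H]2CC[C@]1(C)N(Cc1cn(-c3cccc(Br)c3)nn1)C(=O)C2`: not yet measured

In a functional assay on PANC-1 cells (Homo sapiens) for inhibition, read by MTT assay, with a stated time of 24 h (a lower number here means a stronger inhibitor, a higher number a weaker inhibitor), compound 2 gives 280 nM, which lies within the scatter of compound 1 at 260 nM. Compound 3 keeps the shared core and changes one group, bromo in place of hydroxy on an aromatic carbon. For the measured compounds named here, only one measured step bears on this exchange. It is a 1.1-fold higher number from compound 1 to compound 2 (0.03 log units; within the scatter), where hydroxy replaced chloro on an aromatic carbon. Going by the values given here, no bromo compound has been measured yet, so this single pair is a thin guide. With a 1.1-fold higher number from compound 1 to compound 2 (0.03 log units; within the scatter) as that guide, no step beyond the scatter is expected in this assay. The estimate means a 1.1-fold lower number from compound 2 to compound 3 (0.03 log units; within the scatter), an expected change too small to distinguish from scatter. Compound 3 is expected at about 260 nM, with an estimated range of 130 nM to 520 nM.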

Compound 3, half-maximal inhibitory concentration: 90 nM
Estimate against measurement, compound 3: 2.9-fold (0.46 log units) above; measured number outside the range, below it.
By their numbers in this assay, from the lowest: compound 3; then compounds 1 and 2 (each within the scatter of the next).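

In this assay the group on this aromatic carbon can clearly move the number: bromo in place of hydroxy gives a 3.1-fold lower number from compound 2 to compound 3 (0.49 log units; beyond the scatter) and bromo in place of chloro gives a 2.9-fold lower number from compound 1 to compound 3 (0.46 log units; beyond the scatter) as a second modest step beyond the scatter. Hydroxy and chloro had looked interchangeable at this place, so the earlier pair gave no sign that the position responds to such an exchange at all, and bromo now stands apart from both. Nothing measured here explains why bromo differs from the other two groups.

For the compounds shown here, only three groups have been compared at this one place, so it remains open whether the lower number is particular to bromo. An iodo, a methyl or a trifluoromethyl group, or an amine, on the same carbon would help to settle that.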